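The source may hold more compounds than are shown below. What is called first, only, known or untested is meant among the compounds shown, and "the series" means these compounds.

Compound 2 `CC(C)OC(=O)N1CCC(n2ncc3cc(-c4cc(F)c(C(N)=O)cc4F)ncc32)CC1` gives 52 nM in a functional assay on HEK293 cells for agonist activity at Glucose-dependent insulinotropic receptor (Homo sapiens), read by cAMP accumulation, with a stated time of 30 min; a higher number here means that more compound is needed for the effect, a lower number that less compound is needed. For the measured compounds named here, its only measured neighbour, compound 1 `CC(C)OC(=O)N1CCC(n2ncc3cc(-c4ccc(C(N)=O)cc4F)ncc32)CC1`, gives 97 nM in this assay, and the two lie within the scatter of each other: a 1.9-fold lower number from compound 1 to compound 2 (0.27 log units; within the scatter). Compound 3 `CC(C)OC(=O)N1CCC(n2ncc3cc(-c4cc(F)c(C(=O)N(C)C)cc4F)ncc32)CC1` differs from compound 2 in one place: dimethylamino in place of amino on a carbonyl carbon. Going by the values given here, no measured step touches the carbonyl or its amino group; the single step at hand concerns a fluoro on an aromatic carbon and carries no information on this change. The writer therefore expects compound 3 to move by a 2.9-fold higher number from compound 2 to compound 3 (0.46 log units; beyond the scatter) in this assay, with wide uncertainty. Compound 3 is estimated at 150 nM, with a range from 40 nM to 600 nM.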

Compound 3, half-maximal effective concentration: 46 nM
Compound 3: middle estimate off by 3.3-fold (0.51 log units), on the high side; measured number inside the range.
By their numbers in this assay, from the lowest: compounds 3, 2 and 1 (each within the scatter of the next, the first and the last beyond it).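

On the carbonyl carbon, dimethylamino in place of amino gives a 1.1-fold lower number from compound 2 to compound 3 (0.05 log units; within the scatter) in this assay, so this first change at the amide leaves compound 3 and compound 2 within the scatter of each other. Within this pair, the hydrogen-bond donor of the amino group can go and two more carbons can enter with no change beyond the scatter. Nothing on hand explains this result.

On these data alone, it remains open whether a carboxylic acid, a nitrile or a morpholine amide on that carbon would also stay within the scatter of compound 2. As far as these compounds go, it also remains open whether dimethylamino would give the same result on the core of compound 1.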